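Working notes: from compound 2 to compound 3

The compounds below may be only part of what the source reports. "The series", "measured", "known", "first", "only" and "open" are said of these compounds alone.

Measured so far in a physicochemical assay for lipophilicity, at pH 7.4; a higher number here means a more lipophilic compound, a lower number a more polar compound:
Compound 1 `Cc1cc(NC(=O)CC(C)(C)C)nn1Cc1cc(Cl)ccc1OCc1ccccc1`: > 3.7
Compound 2 `Cc1cc(NC(=O)OCc2ccccn2)nn1Cc1cc(Cl)ccc1OCc1ccccc1`: 3.1

The value of compound 1 is a limit, not a number. In this assay, for the measured compounds named here, compound 2 gives 3.1, the only exact number so far. Compound 3 `COC(=O)Nc1cc(C)n(Cc2cc(Cl)ccc2OCc2ccccc2)n1` is still unmeasured and differs from compound 2 as follows: hydrogen in place of pyridin-2-yl on a saturated chain carbon bound to an oxygen next to a carbonyl group. The same difference reads (pyridin-2-yl)methoxy to methoxy. Going by the values given here, one measured step bears on it, a number at least 0.60 log units lower from compound 1 to compound 2 (beyond the scatter), with (pyridin-2-yl)methoxy in place of neopentyl on a carbonyl carbon. That step gives only a bound, given (the limit of > 3.7 in this assay, at which 1 of the 2 values shown sits), and it does not isolate pyridin-2-yl. A small change is therefore expected, and the estimated step in this assay is a number 0.10 log units lower from compound 2 to compound 3 (within the scatter), not expected to exceed the scatter. For compound 3 the estimate is 3, with an expected range of 2.6 to 3.5.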

Compound 3, distribution coefficient: > 3.7
Compound 3: a limit, no number; the forecaster's own chance of this, stated with the estimate: 5%; middle value at least 0.70 log units away from the limit.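

In this assay, hydrogen in place of pyridin-2-yl on a saturated chain carbon bound to an oxygen next to a carbonyl group gives a number at least 0.60 log units higher from compound 2 to compound 3 (beyond the scatter). Compound 3 gives > 3.7, which is a limit and not a number. The earlier step exchanged the whole (pyridin-2-yl)methoxy for neopentyl, whereas this pair isolates pyridin-2-yl, and its loss alone is enough for a step beyond the scatter.

Methoxy in place of neopentyl on a carbonyl carbon cannot be read from compound 1 to compound 3, with both ends at the same limit: the limit of > 3.7 in this assay, at which 2 of the 3 values shown sit. From the compounds shown here alone, it remains open how far compound 3 lies past its limit, and whether an amine or a longer chain in place of pyridin-2-yl would give a readable number.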